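The source may report more compounds than this note shows. Statements on the series, on what has been measured and on what is new or still open speak of the compounds shown alone.

Measured so far, in a functional assay on the whole organism (strain C57B/6) with Mus musculus as the target, in the maximal electroshock model; on this read-out lower numbers stand for an effect already at smaller amounts and higher numbers for an effect only at larger amounts of compound:
compound 1 `CCc1nncn1-c1ccc(OCc2ccc(F)cc2)cc1` gives 22.8 mg/kg
compound 2 `CCc1nncn1-c1ccc(OCc2cccc(Cl)c2)cc1` gives 27.4 mg/kg

Compound 2 holds the highest of the two numbers, but its nearest neighbour is compound 1, and the step from the one to the other 1.2-fold higher number from compound 1 to compound 2 (0.08 log units; within the scatter) is within the scatter, so the two cannot be told apart on these data. Compound 3 `CCCOc1ccc(-n2cnnc2CC)cc1` is not yet measured. It differs from compound 2 in one place: ethyl in place of 3-chlorophenyl on a saturated chain carbon bound to an oxygen on an aromatic ring. Within the data shown here, the only measured step, a 1.2-fold higher number from compound 1 to compound 2 (0.08 log units; within the scatter), swaps one aromatic ring for another on that same carbon; it says nothing about taking the ring away altogether, as happens here. There is thus no measured guide for this change, and the expectation can only be loose. A loss of the ring is expected to shift the number upward, beyond the scatter, as a 1.6-fold higher number from compound 2 to compound 3 (0.22 log units; within the scatter). Compound 3 is therefore expected to give about 45 mg/kg in this assay, within a range from 18 mg/kg to 120 mg/kg.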

Compound 3, dose for half-maximal effect: > 100 mg/kg
Compound 3 was reported as a limit (the forecaster's own chance of this, stated with the estimate: 20%); middle value at least 2.2-fold (0.34 log units) from the limit.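

In this assay, compound 3 is reported only as a limit, not as a number: the limit of > 100 mg/kg in this assay, at which 1 of the 3 values shown sits. Even so, the steps can be read as minimum sizes: ethyl in place of 3-chlorophenyl gives an at least 3.6-fold higher number from compound 2 to compound 3 (0.56 log units; beyond the scatter), and ethyl in place of 4-fluorophenyl gives an at least 4.3-fold higher number from compound 1 to compound 3 (0.64 log units; beyond the scatter). The earlier swap of one aromatic ring for another stayed within the scatter, whereas these steps show that, among these three compounds, replacing the ring on this saturated chain carbon with ethyl costs effect in the whole animal.

Going by these compounds, how far compound 3 lies past its limit remains unknown, so the full size of both steps is open. The compounds shown also cannot separate the ring itself from the larger group as such: an unsubstituted phenyl, a cyclohexyl ring or a longer chain such as hexyl at this carbon would address that.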